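The source may hold more compounds than are shown below. What is called first, only, known or untested is meant among the compounds shown, and "the series" means these compounds.

Of the compounds shown here, two have been measured in a functional assay on L1210 cells (Mus musculus) for inhibition, with a stated time of 72 h; a higher number here means a weaker inhibitor, a lower number a stronger inhibitor: compound 1 `CN(Cc1ccccc1)Cc1ncnc2c1ncn2[C@@H]1O[C@H](CO)[C@@H](O)[C@H]1O` gives 4800 nM; compound 2 `CC(C)N(Cc1ncnc2c1ncn2[C@@H]1O[C@H](CO)[C@@H](O)[C@H]1O)C(C)C` gives 17000 nM.

Compound 2 stands as the higher, weaker, of the two numbers, separated from compound 1 by a 3.5-fold higher number from compound 1 to compound 2 (0.55 log units; beyond the scatter). Compound 3 `OC[C@H]1O[C@@H](n2cnc3c(CN4CCCCC4)ncnc32)[C@H](O)[C@@H]1O` differs from compound 2 by piperidin-1-yl in place of diisopropylamino on a saturated chain carbon bound to an aromatic carbon. For the measured compounds named here, no measured step involves piperidin-1-yl, so only the step from compound 1 to compound 2 bears on it, and loosely: it shows that changing the group on the saturated chain carbon bound to an aromatic carbon moves the number modestly. For compound 3 a modest fall in the number is expected, a 2.1-fold lower number from compound 2 to compound 3 (0.33 log units; beyond the scatter). Compound 3 is estimated at 8000 nM, between 3000 nM and 25000 nM.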

Compound 3, half-maximal inhibitory concentration: 12200 nM
Beside the measured number, compound 3's estimate is 1.5-fold (0.18 log units) below it; the measured number falls inside the stated range.
By their numbers in this assay, from the lowest: compound 1; then compounds 3 and 2 (each within the scatter of the next).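

In this assay, closing the open diisopropylamino group into the piperidin-1-yl ring gives a 1.4-fold lower number from compound 2 to compound 3 (0.14 log units; within the scatter), so at this saturated chain carbon the ring and the open group cannot be told apart. Replacing benzyl(methyl)amino with piperidin-1-yl gives a 2.5-fold higher number from compound 1 to compound 3 (0.41 log units; beyond the scatter), and among these three compounds only compound 1, with its benzyl(methyl)amino group, stands apart as the stronger inhibitor. Going by these compounds, whether a morpholin-4-yl ring or a primary amine would fit with the piperidin-1-yl result or with compound 1 remains open. Nothing available explains why these numbers differ.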